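Chain Lengthening at the Azepane in Sigma Receptor Binders

This account rests on a few compounds, and the source may have more. Where it says the series, first, only, none or still open, it means among the compounds named here.

In an assay on cell membranes for displacement of a labelled ligand from Sigma non-opioid intracellular receptor 1 (Rattus norvegicus) (a higher number here means a weaker inhibitor, a lower number a stronger inhibitor), the three measured compounds gave the following results.
Compound 1 `CCC(=O)c1ccc2c(c1)sc(=O)n2CCN1CCCCCC1`: 4.5 nM
Compound 2 `CCC(=O)c1ccc2c(c1)sc(=O)n2CCCN1CCCCCC1`: 3.7 nM
Compound 3 `CCCC(=O)c1ccc2c(c1)sc(=O)n2CCCCN1CCCCCC1`: 4.8 nM

Compound 2 differs from compound 1 by (azepan-1-yl)methyl in place of azepan-1-yl on a saturated chain carbon, two bonds along the chain from an aromatic nitrogen, and this change gave a 1.2-fold lower number from compound 1 to compound 2 (0.09 log units; within the scatter). Compound 4 `CCCC(=O)c1ccc2c(c1)sc(=O)n2CCCCCN1CCCCCC1` differs from compound 3 by (azepan-1-yl)methyl in place of azepan-1-yl on a saturated chain carbon, four bonds along the chain from an aromatic nitrogen. The change is of the same kind, but not the same: in the first pair it sits two bonds along the chain from an aromatic nitrogen, in the second pair four bonds along the chain. The difference between the cores of compound 3 and compound 1 is not broken down here.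

For compound 4 a step of a 1.1-fold lower number from compound 3 to compound 4 (0.03 log units; within the scatter) is expected, because a 1.2-fold lower number from compound 1 to compound 2 (0.09 log units; within the scatter) stayed within the scatter. Compound 4 is therefore estimated at 4.5 nM in this assay, expected to fall between 2.2 nM and 9.5 nM.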

Compound 4, inhibition constant: 16.3 nM
The estimate for compound 4 lay 3.6-fold (0.56 log units) below the measured number, and the stated range ends below it.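

In this assay the new step is a 3.4-fold higher number from compound 3 to compound 4 (0.53 log units; beyond the scatter) and so goes beyond the scatter, whereas the same kind of change in the earlier pair did not. Set side by side, the two steps differ, so the earlier result did not carry over to this core: the same change on two cores in this assay, a 1.2-fold lower number (0.09 log units; within the scatter) from compound 1 to compound 2 and a 3.4-fold higher number (0.53 log units; beyond the scatter) from compound 3 to compound 4, 4.1-fold (0.62 log units) apart, beyond the scatter of two such steps.
This does not show whether the core or the place of the change accounts for the gap, since the two pairs differ in both.

The compounds shown leave open how the number would move with a longer chain on either core. They also leave open whether another amine in place of azepan-1-yl would give the same steps.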